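The compounds below may be only part of what the source reports. "The series", "measured", "known", "first", "only" and "open" are said of these compounds alone.

Compound 1, `CCOc1cc(-c2ccc3[nH]ccc3c2)cn2c(-c3cc(OC)c(OC)c(OC)c3)nnc12`: 589 nM
Compound 2, `COc1cc(-c2nnc3c(OC)cc(-c4ccc5[nH]ccc5c4)cn23)cc(OC)c1OC`: 167 nM

Among the measured compounds shown here, in a functional assay on A549 cells (Homo sapiens) for antiproliferative activity, read by MTT assay, with a stated time of 48 h (on this read-out higher numbers stand for weaker inhibition and lower numbers for stronger inhibition), compound 2 gives the lower of the two numbers; compound 1 stands nearest, and the one measured step, a 3.5-fold lower number from compound 1 to compound 2 (0.55 log units; beyond the scatter), concerns an oxygen-bound methyl and touches no part of the fused two-ring system. Compound 3, `COc1cc(-c2nnc3c(OC)cc(-c4ccc5[nH]cc(C=O)c5c4)cn23)cc(OC)c1OC`, keeps the whole of compound 2 and differs only there: formyl in place of hydrogen on an aromatic carbon. Read one bond further out, 1H-indol-5-yl becomes 3-formyl-1H-indol-5-yl. For the measured compounds named here, no measured step bears on this change, so the size of the step in this assay cannot be read from the data; without a guide the expectation is a step of the order of the scatter, in either direction. Compound 3 is therefore estimated at 220 nM, with a range from 60 nM to 800 nM, which means an expected step of a 1.3-fold higher number from compound 2 to compound 3 (0.12 log units; within the scatter).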

Compound 3, half-maximal inhibitory concentration: > 10000 nM
Compound 3: no number, only a limit; the forecaster's own chance of this, stated with the estimate: 3%; middle value at least 45-fold (1.65 log units) away from the limit.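

In this assay compound 3 gives > 10000 nM, which is a limit of the assay and not a number: the limit of > 10000 nM in this assay, at which 1 of the 3 values shown sits.

Among the compounds shown here, the only earlier step, a 3.5-fold lower number from compound 1 to compound 2 (0.55 log units; beyond the scatter), concerned an oxygen-bound methyl and left the fused two-ring system untouched. For the compounds shown here, this change reaches that system for the first time, with formyl in place of hydrogen on the aromatic carbon two ring bonds from the ring nitrogen, and it gives an at least 59-fold higher number from compound 2 to compound 3 (1.77 log units; beyond the scatter). In this assay, then, 3-formyl-1H-indol-5-yl does not retain the activity of 1H-indol-5-yl, and the step is large where the earlier one was modest.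

With a single replacement of hydrogen at this carbon, the compounds shown cannot separate an effect of formyl itself from that of any group placed there. As far as these compounds go, how a methyl, an amine or a carboxylic acid on this carbon would read in this assay stays open.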